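Dose-response notes on a small amide and lactam series

The compounds below may be only part of what the source reports. "The series", "measured", "known", "first", "only" and "open" are said of these compounds alone.

Measured compounds:
compound 1, `COc1ccc(C23CCC(=O)N2CCCO3)cc1`: < 150 mg/kg
compound 2, `O=C1CCC2(c3ccc(Cl)cc3)OCCCN12`: 81.2 mg/kg
compound 3, `O=C(CCC(=O)c1ccc(Cl)cc1)NCCCO`: 325 mg/kg

In a functional assay on the whole organism (Central nervous system) with Mus musculus as the target (on this read-out higher numbers stand for an effect only at larger amounts of compound and lower numbers for an effect already at smaller amounts), compound 2 gives 81.2 mg/kg. Compound 3 gives in this assay a higher number, 325 mg/kg. How the two cores of compound 2 and compound 3 differ is not broken down here. For compound 1 the result in this assay is only a limit, < 150 mg/kg, and the step that the limit leaves unreadable from compound 2 to compound 1 cannot be sized, owing to the limit of < 150 mg/kg in this assay, at which 1 of the 3 values shown sits.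

The change from compound 2 to compound 1 is methoxy in place of chloro on an aromatic carbon. The same change, at the same place, turns compound 3 into the unmeasured compound 4, `COc1ccc(C(=O)CCC(=O)NCCCO)cc1`: methoxy in place of chloro on an aromatic carbon.

For compound 4 the step from compound 3 is expected to be small, a 1.1-fold lower number from compound 3 to compound 4 (0.03 log units; within the scatter), because a step that the limit leaves unreadable from compound 2 to compound 1 gives no readable size for this change and nothing else in the series sizes it. In this assay compound 4 is thus expected near 300 mg/kg. The expected range for compound 4 runs from 120 mg/kg to 750 mg/kg.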

Compound 4, dose for half-maximal effect: 800 mg/kg
Compound 4: the middle estimate sits 2.7-fold (0.43 log units) below what was measured, outside the stated range (above it).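

In this assay, methoxy in place of chloro on an aromatic carbon of the core of compound 3 gives a 2.5-fold higher number from compound 3 to compound 4 (0.39 log units; beyond the scatter), a step beyond the usual scatter and the only readable size for this change in the series. The step from compound 2 to compound 1 cannot be read, so neither its size nor its direction can be set against the new step, because the value of compound 1 is a limit and not a number: the limit of < 150 mg/kg in this assay, at which 1 of the 4 values shown sits. The new step therefore shows what this change does on one core only; it does not show that the change carries to the core of compound 2, and a single readable pair makes no pattern.

Going by these compounds, what an amine or a carboxylic acid would do in place of chloro on that aromatic carbon remains open on both cores. Also open, on these data alone, is whether a longer chain in place of methoxy would follow the step seen on the core of compound 3.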